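Swapping a Bulky Alkyl for a Chlorinated Benzyl

The source may hold more compounds than are shown below. What is called first, only, known or untested is meant among the compounds shown, and "the series" means these compounds.

Measured so far:
- Compound 1, `CCCCc1cnc(CCCc2ccc(-c3ccccc3C(=O)O)cc2)[nH]1`: 5600 nM
- Compound 2, `CC(C)(C)Cc1cnc(CCc2ccc(-c3ccccc3C(=O)O)cc2)[nH]1`: 106 nM
- Compound 3, `CCCCc1cnc(/C=C/c2ccc(-c3ccccc3C(=O)O)cc2)[nH]1`: 4380 nM

In an in vitro functional assay on cells for agonist activity at Bombesin receptor subtype-3 (Homo sapiens), read by luminescence and calcium flux (on this read-out higher numbers stand for an effect only at larger amounts of compound and lower numbers for an effect already at smaller amounts), compound 2 gives 106 nM, the lowest of the three numbers, so it acts at the smallest amount of compound. Its nearest neighbour is compound 3, whose value of 4380 nM lies beyond the scatter, and compound 1 at 5600 nM lies further still. The untested compound 4, `O=C(O)c1ccccc1-c1ccc(CCc2ncc(Cc3cccc(Cl)c3)[nH]2)cc1`, keeps the core of compound 2 and differs in a single place: 3-chlorophenyl in place of tert-butyl on a saturated chain carbon bound to an aromatic carbon. Going by the values given here, no pair of measured compounds shows this kind of exchange, so its effect can only be guessed from the general picture that the group at this position matters a great deal. A step of moderate size toward a higher number is expected, from compound 2 to compound 4 of about a 3.8-fold higher number from compound 2 to compound 4 (0.58 log units; beyond the scatter). Compound 4 is therefore estimated at 400 nM in this assay, within a wide range from 60 nM to 3000 nM.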

Compound 4, half-maximal effective concentration: 825 nM
Compound 4: middle estimate off by 2.1-fold (0.31 log units), on the low side, and the stated range covers the measured number.
By their numbers in this assay, from the lowest: compound 2; then compound 4; then compounds 3 and 1 (each within the scatter of the next).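

In this assay, exchanging neopentyl for 3-chlorobenzyl gives a 7.8-fold higher number from compound 2 to compound 4 (0.89 log units; beyond the scatter), the first change in a single place among these compounds. The position therefore accepts a group carrying a six-membered aromatic ring in place of the branched tert-butyl end, with 7 heavy atoms entering where 4 leave, at the price of needing more compound for the same effect, yet compound 4 still gives 825 nM. Nothing measured here explains why the number rises.

The compounds shown leave open whether the rise goes with the aromatic ring itself or with its chlorine, a question that a plain benzyl group would help to settle. A cyclohexylmethyl group would likewise show whether a ring without aromatic character reads closer to neopentyl or to 3-chlorobenzyl.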